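Swapping nitro for fluoro on the aryl hydrazone of compound 2

The source may report more compounds than this note shows. Statements on the series, on what has been measured and on what is new or still open speak of the compounds shown alone.

Of the compounds shown here, two sharing one core have been measured in an ADME assay on THP-1 cells (Homo sapiens) for cytotoxicity; on this read-out higher numbers stand for weaker inhibition and lower numbers for stronger inhibition. Compound 1 `COc1ccccc1-c1nnc(-c2ccc(C(=O)N/N=C/c3cccc([N+](=O)[O-])c3)cc2)o1` gives 119000 nM, and compound 2 `COc1ccccc1-c1nnc(-c2ccc(C(=O)N/N=C/c3ccccc3[N+](=O)[O-])cc2)o1` gives 161000 nM. Among the compounds with values here, the only measured step, a 1.4-fold higher number from compound 1 to compound 2 (0.13 log units; within the scatter), moves the nitro group from one position to another and lies within the scatter, so the two numbers for compound 1 and compound 2 cannot be told apart.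

Compound 3 `COc1ccccc1-c1nnc(-c2ccc(C(=O)N/N=C/c3ccccc3F)cc2)o1` differs from compound 2 in one place: fluoro in place of nitro on an aromatic carbon. Within the data shown here, no measured pair covers a nitro-to-fluoro exchange, and the single step from compound 1 to compound 2 concerns the position of the nitro group, not its identity, so nothing in the data bears directly on this change. Among the measured compounds shown here, with the one available step lying within the scatter, the account expects no movement beyond the scatter in this assay for compound 3, and the expected step is a 1.0-fold lower number from compound 2 to compound 3 (0.00 log units; within the scatter). The estimate for compound 3 in this assay is 160000 nM, with a range from 60000 nM to 420000 nM.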

Compound 3, half-maximal inhibitory concentration: 313000 nM
Compound 3: middle estimate off by 2.0-fold (0.29 log units), on the low side; the range from low to high includes it.
By their numbers in this assay, from the lowest: compounds 1, 2 and 3 (each within the scatter of the next, the first and the last beyond it).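

Placing fluoro on this aromatic carbon, ortho to a large group, gives a 1.9-fold higher number from compound 2 to compound 3 (0.29 log units; within the scatter) in this assay, so at this position a nitro group and a single fluorine atom cannot be told apart on this read-out. The 2-fluorophenyl group in place of 3-nitrophenyl gives a 2.6-fold higher number from compound 1 to compound 3 (0.42 log units; beyond the scatter), the first modest separation in the series, but this step changes both the group and its position, and each of the two smaller steps that link these compounds lies within the scatter, so it cannot be assigned to either change alone. No measurement offered here accounts for this separation.

The compounds shown leave open whether fluoro would read the same at the position the nitro group holds in compound 1, which would separate the effect of the group from that of its place. They also leave open whether a more different group on this aromatic carbon, such as an amine or a carboxylic acid, would move the number in this assay clearly beyond the scatter from compound 2.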